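Series notes: a nitro placed ortho to the phenylsulfonyl group

The compounds below may be only part of what the source reports. "The series", "measured", "known", "first", "only" and "open" are said of these compounds alone.

Measured so far:
compound 1 `CC(O)(C(=O)Nc1cccc(S(=O)(=O)c2ccccc2)c1)C(F)(F)F` — in a functional assay (Cavia porcellus) with sulfonylurea receptors; K-ATP channels (Homo sapiens) as the target (on this read-out higher numbers stand for weaker inhibition and lower numbers for stronger inhibition), compound 1 gives > 30000 nM, a limit of the assay.
compound 2 `CC(O)(C(=O)Nc1ccc(S(=O)(=O)c2ccccc2)c([N+](=O)[O-])c1)C(F)(F)F` — in this assay compound 2 gives > 30000 nM, also a limit of the assay.

Compound 1 stands at the limit of > 30000 nM in this assay, at which 2 of the 2 values shown sit. Its value is not a number but a limit, so no ranking among the measured compounds can be drawn from it. Among the measured compounds shown here, the value of compound 2 is a limit in the same way, and no step between compound 1 and compound 2 is worked out here; their two values show only that both sit at the limit.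

The next compound, compound 3 `CC(O)(C(=O)Nc1ccc([N+](=O)[O-])c(S(=O)(=O)c2ccccc2)c1)C(F)(F)F`, has not been measured. It differs from compound 1 by nitro in place of hydrogen on an aromatic carbon. For the measured compounds named here, no measured step gives a direction for such a change in this assay, and both measured values are limits. The step from compound 1 to compound 3 is therefore expected to be none beyond the scatter, a step that the limit leaves unreadable from compound 1 to compound 3. Compound 3 is expected to give about 40000 nM, within 15000 nM to 100000 nM, most likely reported as a limit again.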

Compound 3, half-maximal inhibitory concentration: > 30000 nM
Compound 3 was reported as a limit; the forecaster's own chance of this, stated with the estimate: 80%; the middle value does not contradict the limit.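

Compound 1 and compound 3 both sit at a limit of the assay in this assay, so no step can be read for nitro in place of hydrogen on an aromatic carbon: the limit of > 30000 nM in this assay, at which 3 of the 3 values shown sit. The compounds shown leave open whether this nitro, ortho to a phenylsulfonyl group, changes inhibition at all, and whether any compound here gives a measurable value.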